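Nitro in place of methoxy on compound 3

This account rests on a few compounds, and the source may have more. Where it says the series, first, only, none or still open, it means among the compounds named here.

In a functional assay on BGC-823 cells (Homo sapiens) for inhibition, read by MTT assay, with a stated time of 72 h (a higher number here means a weaker inhibitor, a lower number a stronger inhibitor), compound 1 `Cc1cc(N2CC[C@@H](C)[C@@H](N(C)c3ncnc4[nH]ccc34)C2)n2nc(SCc3nc4ccccc4[nH]3)nc2n1` reads > 100000 nM, which is a limit of the assay. Compound 2 `Cc1cc(N2CC[C@@H](C)[C@@H](N(C)c3ncnc4[nH]ccc34)C2)n2nc(SCC3CCCCC3)nc2n1` gives 16300 nM, and compound 3 `COc1ccc(CSc2nc3nc(C)cc(N4CC[C@@H](C)[C@@H](N(C)c5ncnc6[nH]ccc56)C4)n3n2)cc1` gives 69900 nM, the higher of the two actual numbers. Compound 4 `Cc1cc(N2CC[C@@H](C)[C@@H](N(C)c3ncnc4[nH]ccc34)C2)n2nc(SCc3ccc([N+](=O)[O-])cc3)nc2n1` carries nitro in place of methoxy on an aromatic carbon, para to a large group: nitro in place of methoxy on an aromatic carbon. Within the data shown here, no measured step makes this exact change. The closest, a 4.3-fold higher number from compound 2 to compound 3 (0.63 log units; beyond the scatter), replaces the whole group on the chain. The other, an at least 1.4-fold lower number from compound 1 to compound 3 (0.15 log units; that floor lies within the scatter), is also such a replacement. A small change, not clearly beyond the scatter, is therefore expected: a 1.3-fold lower number from compound 3 to compound 4 (0.10 log units; within the scatter). Compound 4 is estimated at 55000 nM, with an expected range of 18000 nM to 100000 nM.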

Compound 4, half-maximal inhibitory concentration: 59600 nM
Compound 4: the middle estimate sits 1.1-fold (0.03 log units) below what was measured; measured number inside the range.
By their numbers in this assay, from the lowest: compound 2; then compounds 4 and 3 (each within the scatter of the next). At a limit, above all of these: compound 1.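

In this assay, nitro in place of methoxy on an aromatic carbon, para to a large group, gives a 1.2-fold lower number from compound 3 to compound 4 (0.07 log units; within the scatter). This is the first change shown that keeps the ring and alters only its substituent, and the two groups are not told apart here, while cyclohexyl still reads lower beyond the scatter (a 3.7-fold higher number from compound 2 to compound 4 (0.56 log units; beyond the scatter)). With 4-nitrophenyl in place of 1H-benzimidazol-2-yl, the data give an at least 1.6-fold lower number from compound 1 to compound 4 (0.22 log units; that floor lies within the scatter). That step is only a floor, as compound 1 stands at a limit: (the limit of > 100000 nM in this assay, at which 1 of the 4 values shown sits).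

Going by these compounds, whether an amine or a carboxylic acid at this carbon would move the number stays open, as does the effect of a longer chain in place of cyclohexyl.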